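Swapping trifluoromethyl for methoxy on two related cores

This account rests on a few compounds, and the source may have more. Where it says the series, first, only, none or still open, it means among the compounds named here.

Four compounds share a side arm built from a six-membered aromatic ring of carbon only, linked through a double bond to a small ring, and they are compared in a functional assay on MCF7 cells (Homo sapiens) for inhibition, read by sulforhodamine B assay, with a stated time of 48 h; on this read-out lower numbers stand for stronger inhibition of growth and higher numbers for weaker inhibition of growth. Compound 1 `O=C1C=CCC(/C=C/c2ccc(C(F)(F)F)cc2)O1` gives 51 uM. Compound 2 `COc1ccc(/C=C/C2CC=CC(=O)O2)cc1` carries the change methoxy in place of trifluoromethyl on an aromatic carbon and gives 25.5 uM. The step that this change made, a 2.0-fold lower number from compound 1 to compound 2 (0.30 log units; within the scatter), is small enough to sit inside the ordinary spread of repeated runs.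

Compound 3 `O=C1C=CCC(/C=C/c2ccc(C(F)(F)F)cc2)N1` has a different core; how it differs from the core of compound 1 is not broken down here. In this assay compound 3 gives 150 uM, the highest of the three measured numbers and beyond the usual spread from compound 1 and from compound 2.

Compound 4 `COc1ccc(/C=C/C2CC=CC(=O)N2)cc1` has not been measured. It stands to compound 3 as compound 2 stands to compound 1: the change (methoxy in place of trifluoromethyl on an aromatic carbon), described in the same words at the same place, so it is the same change on a different core. Among the compounds with values here, the only guide is the one measured step. The step from compound 3 to compound 4 is expected to be a 2.0-fold lower number from compound 3 to compound 4 (0.30 log units; within the scatter), resting on the earlier 2.0-fold lower number from compound 1 to compound 2 (0.30 log units; within the scatter). Compound 4 is therefore estimated at 75 uM, with a likely range from 35 uM to 160 uM, and a wider range than for a measured pair, since a single step carries limited weight.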

Compound 4, concentration for growth inhibition (reported as GI): > 1090 uM
Compound 4: only a limit was reported; the forecaster's own chance of this, stated with the estimate: 10%; middle value at least 14-fold (1.16 log units) away from the limit.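

In this assay compound 4 gives > 1090 uM, which is a limit of the assay and not a number. Even so, the change of methoxy in place of trifluoromethyl gives an at least 7.2-fold higher number from compound 3 to compound 4 (0.86 log units; beyond the scatter), so on this core it goes with clearly weaker inhibition of growth, and the result from the core of compound 1 does not carry over: the same change on two cores in this assay, a 2.0-fold lower number (0.30 log units; within the scatter) from compound 1 to compound 2 and an at least 7.2-fold higher number (0.86 log units; beyond the scatter) from compound 3 to compound 4, at least 14-fold (1.16 log units) apart, beyond the scatter of two such steps This shows that, in this small series, the step measured on one core is a poor guide to the step on the other, but it does not show why the two cores answer so differently, how large the step from compound 3 really is, or how the change would behave on any further core.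

The compounds shown leave open whether this split is specific to methoxy and trifluoromethyl, a question that pairs on both cores carrying a chlorine atom, a hydroxyl group or an amine at the same aromatic carbon could address. They also leave open whether the difference between the cores would appear in other cell lines, as all four compounds are compared on a single cell type with a single read-out.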